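Methyl in place of hydrogen: compound 3 to compound 4

A few compounds are considered here, and "the series" means these few. Any claim that something is new, unique, unknown or untested is made for them only; others in the source may bear on it.

In a functional assay with Cavia porcellus as the target (on this read-out lower numbers stand for an effect already at smaller amounts and higher numbers for an effect only at larger amounts of compound), compound 3 `COC(=O)c1c[nH]cc1C(=O)c1ccccc1Cc1ccccc1` gives 2100 nM, the second highest of three numbers. Compound 1 `COC(=O)c1c[nH]c(C)c1C(=O)c1ccccc1Cc1ccccc1` gives 144 nM, and compound 2 `COC(=O)c1c(C)[nH]c(C)c1C(=O)c1ccccc1F` gives 70000 nM, though compound 2 differs from compound 3 in more than one place. Compound 4 `COC(=O)c1c(C(=O)c2ccccc2Cc2ccccc2)c[nH]c1C` carries methyl in place of hydrogen on an aromatic carbon, next to the ring nitrogen and next to the ring atom that bears a methoxycarbonyl group. Within the data shown here, the only measured step bearing on this is a 15-fold higher number from compound 1 to compound 3 (1.16 log units; beyond the scatter), which is large, but there the methyl sits on another aromatic carbon. A lower number is therefore expected, by less than that step. The expected step is a 3.0-fold lower number from compound 3 to compound 4 (0.48 log units; beyond the scatter). For compound 4 the estimated value is 700 nM, with an expected range of 150 nM to 3000 nM.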

Compound 4, half-maximal effective concentration: 460 nM
Beside the measured number, compound 4's estimate is 1.5-fold (0.18 log units) above it, and the stated range covers the measured number.
By their numbers in this assay, from the lowest: compound 1; then compound 4; then compound 3; then compound 2.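

This position responds to methyl: in this assay, methyl in place of hydrogen next to the ring nitrogen gives a modest gain, beyond the scatter (a 4.6-fold lower number from compound 3 to compound 4 (0.66 log units; beyond the scatter)). The earlier step (a 15-fold higher number from compound 1 to compound 3 (1.16 log units; beyond the scatter)) covered only the methyl on another aromatic carbon, so the lower number with methyl over hydrogen now holds at both carbons, with no compound shown against it. Nothing measured here accounts for this gain.

Going by these compounds, whether an ethyl group or an amine at this carbon would keep the lower number remains open. So does the effect of methyl on both carbons with the large group of compound 3 kept.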